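The source may report more compounds than this note shows. Statements on the series, on what has been measured and on what is new or still open speak of the compounds shown alone.

Compound 1, with the structure `CN(C)CCCOc1ccc(CN2CC[C@H](NC(=O)c3cc(Cl)cc(Cl)c3)C2)cc1`, carries a 3,5-dichlorophenyl on the carbonyl carbon of its amide. In an assay on HEK293 cells for binding affinity to Urotensin-2 receptor (Homo sapiens), read by radioligand binding (on this read-out higher numbers stand for weaker inhibition and lower numbers for stronger inhibition), compound 1 gives 2000 nM. Compound 2, with the structure `COc1ccc(C(=O)N[C@H]2CCN(Cc3ccc(OCCCN(C)C)cc3)C2)cc1OC`, carries a 3,4-dimethoxyphenyl in the same position. In this assay compound 2 returns only a limit, < 10000 nM, so compound 2 stands at the edge of what the assay reports rather than on a number. The step from compound 1 to compound 2 in this assay is therefore a step that the limit leaves unreadable from compound 1 to compound 2, and its size cannot be read, as the limit of < 10000 nM in this assay, at which 1 of the 2 values shown sits, notes.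

Compound 3, with the structure `CN(C)CCCOc1ccc(CN2CC[C@H](NC(=O)c3ccncc3)C2)cc1`, differs from compound 2 by pyridin-4-yl in place of 3,4-dimethoxyphenyl on a carbonyl carbon. For the measured compounds named here, only the step from compound 1 to compound 2 bears on this change, and that step is unreadable, so no direction and no size beyond the scatter can be drawn from it for this assay. The result for compound 3 is therefore expected near the limit itself, with the estimated step that the limit leaves unreadable from compound 2 to compound 3 uncertain. For compound 3 in this assay the estimate is 8000 nM, expected between 2000 nM and 30000 nM.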

Compound 3, inhibition constant: < 10000 nM
Compound 3: a limit, no number; the forecaster's own chance of this, stated with the estimate: 50%; the middle value lies beyond the limit too.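

Compound 3 returns only a limit in this assay, so no new step can be read, neither from compound 2 nor from compound 1: the limit of < 10000 nM in this assay, at which 2 of the 3 values shown sit. The compounds shown leave open how far compound 2 and compound 3 lie from compound 1, and whether pyridin-4-yl and 3,4-dimethoxyphenyl on the carbonyl carbon differ at all.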